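A few compounds are considered here, and "the series" means these few. Any claim that something is new, unique, unknown or untested is made for them only; others in the source may bear on it.

In a functional assay on HT-29 cells (Homo sapiens) for inhibition, read by sulforhodamine B assay, with a stated time of 48 h (a lower number here means a stronger inhibitor of growth, a higher number a weaker inhibitor of growth), the measured compounds stand as follows:

compound 1 `c1cc2c(cc1NC1=NCCO1)CCC2` gives 4900 nM
compound 2 `c1cc(C2CCCCC2)ccc1NC1=NCCO1` gives 12800 nM

Compound 2 at 12800 nM holds the higher of the two numbers, and its gap to compound 1 lies beyond the scatter. Among the compounds with values here, compound 3 `c1ccc(-c2ccc(NC3=NCCO3)cc2)cc1` is not yet measured and has phenyl in place of cyclohexyl on an aromatic carbon as its one change. Within the data shown here, no measured pair tests this change, so the expectation is tentative: a small move toward a lower number, not clearly beyond the scatter. The estimated step of a 1.8-fold lower number from compound 2 to compound 3 (0.26 log units; within the scatter) is expected to be modest. For compound 3 the estimated value is 7000 nM with an expected range from 2500 nM to 20000 nM in this series.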

Compound 3, concentration for 50% growth inhibition: 5800 nM
Compound 3: the middle estimate sits 1.2-fold (0.08 log units) above what was measured; the range from low to high includes it.
By their numbers in this assay, from the lowest: compounds 1 and 3 (each within the scatter of the next); then compound 2.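

In this assay, within the data shown here, phenyl in place of cyclohexyl on an aromatic carbon gives a 2.2-fold lower number from compound 2 to compound 3 (0.34 log units; beyond the scatter), the first step that isolates one place. This position therefore distinguishes an aromatic from a non-aromatic six-membered ring, even with the heavy-atom count unchanged and no hydrogen-bond donors or acceptors on either group. Nothing measured here accounts for this difference.

Going by these compounds, whether an amine, a carboxylic acid or a longer alkyl chain in this same place would give a lower number remains open. So does whether substituents on the entering phenyl would extend the step.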